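Swapping the Aromatic Ring of Compound 2

A few compounds are considered here, and "the series" means these few. Any claim that something is new, unique, unknown or untested is made for them only; others in the source may bear on it.

Among the compounds with values here, in an ADME assay on CEM-SS cells (Homo sapiens) for cytotoxicity, read by XTT assay (on this read-out lower numbers stand for higher toxicity in this test and higher numbers for lower toxicity in this test), compound 2 `O=C(NO)c1cc2ccn(Cc3ccc(F)cc3)c2cn1` gives 159000 nM, the only exact number so far. Compound 1 `O=C(NO)c1cc2ccn(Cc3ccc(F)cc3F)c2cn1` reads > 320000 nM, which is a limit of the assay and not a number. Compound 3 `O=C(NO)c1cc2ccn(Cc3c(F)ccc(Cl)c3F)c2cn1` reads > 1000 nM, which is also a limit. Within the data shown here, the one measured step is an at least 2.0-fold lower number from compound 1 to compound 2 (0.30 log units; that floor lies within the scatter), and it places hydrogen in place of fluoro on an aromatic carbon.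

Compound 4 `O=C(NO)c1cc2ccn(Cc3ccc(Cl)s3)c2cn1` has not yet been measured. It carries 5-chlorothiophen-2-yl in place of 4-fluorophenyl on a saturated chain carbon bound to an aromatic nitrogen. Among the measured compounds shown here, no measured step exchanges a whole ring, so the evidence is thin. For the measured compounds named here, the estimate therefore rests mainly on compound 2 at 159000 nM, with the small step to compound 2 as the only guide to size. The expected change is a 1.6-fold lower number from compound 2 to compound 4 (0.20 log units; within the scatter), which means no clear shift in this assay is anticipated. For compound 4 the estimated value is 100000 nM, with an expected range of 30000 nM to 320000 nM.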

Compound 4, half-maximal cytotoxic concentration: > 10000 nM
Compound 4 was reported as a limit (the forecaster's own chance of this, stated with the estimate: 25%); the middle value does not contradict the limit.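

In this assay compound 4 gives > 10000 nM, which is a limit of the assay and not a number, so the step from compound 2 to compound 4 cannot be read. On these data alone, whether 5-chlorothiophen-2-yl in place of 4-fluorophenyl shifts this read-out at all stays open.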